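Methoxy count on the aryl ring and cell growth inhibition

The source may hold more compounds than are shown below. What is called first, only, known or untested is meant among the compounds shown, and "the series" means these compounds.

Compound 1 `COc1ccc(-c2c(-c3cc(OC)c(OC)c(OC)c3)c(=O)c2=O)cc1OC` gives 210 nM in a functional assay on CCRF-CEM cells (Homo sapiens) for inhibition, read by MTT assay, with a stated time of 72 h (on this read-out lower numbers stand for stronger inhibition and higher numbers for weaker inhibition), the highest of the two numbers measured. Among the measured compounds shown here, compound 2 `COc1ccc(-c2c(-c3cc(OC)c(OC)c(OC)c3)c(=O)c2=O)cc1` gives 16 nM in this assay; the only measured step, a 13-fold lower number from compound 1 to compound 2 (1.12 log units; beyond the scatter), goes with hydrogen in place of methoxy on an aromatic carbon. Compound 3 `COc1cc(-c2c(-c3cc(OC)c(OC)c(OC)c3)c(=O)c2=O)cc(OC)c1OC` reverses that direction: methoxy in place of hydrogen on an aromatic carbon. With one methoxy fewer giving a large drop, a further methoxy on that ring is expected to raise the number in this assay, by about a 3.3-fold higher number from compound 1 to compound 3 (0.52 log units; beyond the scatter). Compound 3 is therefore estimated at 700 nM, between 150 nM and 3000 nM.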

Compound 3, half-maximal inhibitory concentration: > 20000 nM
Compound 3: only a limit was reported; the forecaster's own chance of this, stated with the estimate: 5%; middle value at least 28-fold (1.45 log units) away from the limit.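

Methoxy in place of hydrogen on an aromatic carbon, ortho to a methoxy group, gives an at least 95-fold higher number from compound 1 to compound 3 (1.97 log units; beyond the scatter). Across compounds 2, 1 and 3, the number rises with each added methoxy group on this ring, and no compound shown goes against this. The reading for compound 3 in this assay is a limit and not a number: the limit of > 20000 nM in this assay, at which 1 of the 3 values shown sits.

As far as these compounds go, whether the rise goes with the count of methoxy groups or with the place of the added one stays open. So does the effect of a hydroxyl group, a fluorine atom or an amine on that aromatic carbon.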